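From Methyl to Trifluoromethoxy on a Shared Core

The source may report more compounds than this note shows. Statements on the series, on what has been measured and on what is new or still open speak of the compounds shown alone.

Of the compounds shown here, three built on one shared core have been measured in an assay on brain (strain C57BL6) for displacement of a labelled ligand from AP2-associated protein kinase 1 (Mus musculus), read by scintillation counting, with a stated time of 1 h; on this read-out lower numbers stand for stronger inhibition and higher numbers for weaker inhibition. Compound 1 `CC(=O)Nc1cc(-c2ccc(OC[C@@H](N)CC(C)C)c(F)c2)ccn1` gives 0.52 nM. Compound 2 `CC(=O)Nc1cc(-c2ccc(OC[C@@H](N)CC(C)C)c(C)c2)ccn1` gives 0.08 nM, the lowest of the three numbers. Compound 3 `COC(=O)Nc1cc(-c2ccc(OC[C@@](C)(N)CC(C)C)c(C)c2C)ccn1` differs from compound 2 in several places. Compound 3 gives 0.26 nM. Among the compounds with values here, the only single-point step measured, a 6.5-fold lower number from compound 1 to compound 2 (0.81 log units; beyond the scatter), shows that the group on this aromatic carbon moves the number beyond the scatter.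

Compound 4 `CC(=O)Nc1cc(-c2ccc(OC[C@@H](N)CC(C)C)c(OC(F)(F)F)c2)ccn1` carries a different group at the same spot: trifluoromethoxy in place of methyl on an aromatic carbon. Within the data shown here, no measured step exchanges methyl for trifluoromethoxy, so the step from compound 1 to compound 2 is the only guide, and it tells just that this position is sensitive. Since compound 1 with fluoro gives 0.52 nM against the methyl analogue, a move away from methyl is expected to raise the number in this assay. Compound 4 is therefore estimated at 0.4 nM, with a range from 0.1 nM to 2 nM. That estimate means a step of a 5.0-fold higher number from compound 2 to compound 4 (0.70 log units; beyond the scatter) is expected.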

Compound 4, inhibition constant: 0.04 nM
Compound 4: middle estimate off by 10-fold (1.00 log units), on the high side; the whole stated range lies above it.
By their numbers in this assay, from the lowest: compounds 4 and 2 (each within the scatter of the next); then compounds 3 and 1 (each within the scatter of the next).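

In this assay, the exchange of methyl for trifluoromethoxy gives a 2.0-fold lower number from compound 2 to compound 4 (0.30 log units; within the scatter), so these two groups cannot be told apart at this spot, even though trifluoromethoxy brings an oxygen and three fluorine atoms that methyl lacks. The exchange of fluoro for trifluoromethoxy gives a 13-fold lower number from compound 1 to compound 4 (1.11 log units; beyond the scatter), a large step that compares with a 6.5-fold lower number from compound 1 to compound 2 (0.81 log units; beyond the scatter) for methyl. Among the three groups tried on this aromatic carbon, fluoro is therefore the one that stands apart, and the position's sensitivity does not simply follow the size of the group.

As far as these compounds go, whether a methoxy group, a chlorine atom or a nitrile would sit with fluoro or with the other two groups remains open. No measurement at hand explains why fluoro stands apart.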